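Methoxy gives way to diisopropylamino on a shared core

The source may report more compounds than this note shows. Statements on the series, on what has been measured and on what is new or still open speak of the compounds shown alone.

Within the data shown here, in a functional assay on SMMC-7721 cells (Homo sapiens) for antiproliferative activity, read by MTT assay, with a stated time of 48 h (a higher number here means a weaker inhibitor, a lower number a stronger inhibitor), compound 3 `COC/C1=C/C[C@](C)(CCC=C(C)C)/C=C/[C@@H](OC(=O)C=C(C)C)[C@](C)(O)/C=C/C1=O` gives 11000 nM, the highest of the three numbers measured so far. Compound 2 `COC/C1=C/C[C@](C)(CCC=C(C)C)/C=C/[C@@H](OC(=O)C=C(C)C)[C@](C)(OC)/C=C/C1=O` gives 9380 nM, and compound 1 `CC(=O)OC/C1=C/C[C@](C)(CCC=C(C)C)/C=C/[C@@H](OC(=O)C=C(C)C)[C@](C)(OC(C)=O)/C=C/C1=O` gives 4130 nM, a number lower than that of compound 3 by a margin beyond the scatter. Compound 4 `CC(C)=CCC[C@]1(C)/C=C/[C@@H](OC(=O)C=C(C)C)[C@](C)(O)/C=C/C(=O)/C(CN(C(C)C)C(C)C)=C\C1` has diisopropylamino in place of methoxy on a saturated chain carbon bound to a double-bonded ring carbon. Among the measured compounds shown here, the only measured step is a 1.2-fold higher number from compound 2 to compound 3 (0.07 log units; within the scatter), and it changes a different place in the molecule, so it says little about this one. For the measured compounds named here, compound 1 differs from compound 3 at two places, so its value cannot isolate the effect of this position, and no measured compound carries an amino group there. The data therefore support no expected direction, and the estimated change in this assay is a 1.4-fold lower number from compound 3 to compound 4 (0.14 log units; within the scatter), with none beyond the scatter expected. The estimate for compound 4 is 8000 nM, with an expected range from 2500 nM to 25000 nM.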

Compound 4, half-maximal inhibitory concentration: 340 nM
For compound 4 the middle estimate is 24-fold (1.37 log units) above the measured one; measured number outside the range, below it.
By their numbers in this assay, from the lowest: compound 4; then compound 1; then compounds 2 and 3 (each within the scatter of the next).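

In this assay, putting diisopropylamino in place of methoxy on a saturated chain carbon bound to a double-bonded ring carbon gives a 32-fold lower number from compound 3 to compound 4 (1.51 log units; beyond the scatter), a large step. Among these compounds, the only earlier single-place step, a 1.2-fold higher number from compound 2 to compound 3 (0.07 log units; within the scatter), lies within the scatter and changes another place, so this is the first sign that the number responds strongly to a change in the shared core, and the position named here is where it does so. Nothing shown here accounts for the size of this step.

With one amine at this position, the result cannot separate the role of the nitrogen from that of the two isopropyl groups. On these data alone, whether dimethylamino, morpholine or a plain isopropyl group on the same carbon would give a number near that of compound 4 remains open.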